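This account rests on a few compounds, and the source may have more. Where it says the series, first, only, none or still open, it means among the compounds named here.

Compound 1 `O[C@@H]1[C@@H](O)[C@H](Oc2cccc3c(S)cccc23)OC[C@H]1O` and compound 2 `O[C@@H]1[C@@H](O)[C@H](Oc2ccc3cc(S)ccc3c2)OC[C@H]1O` are built from the same atoms joined in different ways; the difference between the two cores is not broken down here. Both were tested in an ADME assay on HFL1 cells (Homo sapiens) for antiproliferative activity, read by crystal violet staining, with a stated time of 96 h; on this read-out higher numbers stand for an effect only at larger amounts of compound and lower numbers for an effect already at smaller amounts. In this assay compound 1 gives 60 uM, and compound 2 gives 60 uM, so the two stand level at the digits shown and together give the highest numbers of the three measured compounds. Compound 3 `CCCSc1cccc2c(O[C@@H]3OC[C@@H](O)[C@H](O)[C@H]3O)cccc12` differs from compound 1 by one change, (propyl in place of hydrogen on a sulfur). In this assay compound 3 gives 20 uM, which is a 3.0-fold lower number from compound 1 to compound 3 (0.48 log units; beyond the scatter), a modest step that lies beyond the usual scatter.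

Compound 4 `CCCSc1ccc2cc(O[C@@H]3OC[C@@H](O)[C@H](O)[C@H]3O)ccc2c1` has not yet been measured. It differs from compound 2 by the same change, (propyl in place of hydrogen on a sulfur), made at the same kind of place, a sulfur whose only other neighbour is an aromatic carbon. Because compound 1 moved to compound 3 by a 3.0-fold lower number from compound 1 to compound 3 (0.48 log units; beyond the scatter), a similar step is expected here: the estimate is a 3.0-fold lower number from compound 2 to compound 4 (0.48 log units; beyond the scatter). On that basis compound 4 is expected to give about 20 uM in this assay, most likely between 10 uM and 40 uM.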

Compound 4, concentration for half-maximal effect: 30 uM
Compound 4: middle estimate off by 1.5-fold (0.18 log units), on the low side, within the range that was stated.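

In this assay, putting propyl on the sulfur of the core of compound 2 gives a 2.0-fold lower number from compound 2 to compound 4 (0.30 log units; within the scatter), and set beside the earlier step on the core of compound 1, the two cannot be told apart: the same change on two cores in this assay, a 3.0-fold lower number (0.48 log units; beyond the scatter) from compound 1 to compound 3 and a 2.0-fold lower number (0.30 log units; within the scatter) from compound 2 to compound 4, 1.5-fold (0.18 log units) apart, within the scatter of two such steps. As far as these two pairs can show, the change carries over from one core to the other at a similar size. On its own, however, the step on the core of compound 2 stays within the scatter and cannot count as a firm change, and two cores cannot promise the same result on a third.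

The compounds shown carry only hydrogen or propyl on the sulfur, so it stays open how a methyl, a longer chain such as hexyl, or a chain ending in an amine or a carboxylic acid would behave. Also open, from the compounds shown here alone, is whether the size of the step depends on the length of the chain at all.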